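The compounds below may be only part of what the source reports. "The series", "measured", "known", "first", "only" and "open" are said of these compounds alone.

Measured so far:
compound 1 `Cc1ccc2nc(NC(=O)CNC(=O)c3nn(-c4ccccc4)c(=O)c4ccccc34)sc2c1`: 35 nM in an assay on L cells for inhibition of Protein-serine O-palmitoleoyltransferase porcupine (Mus musculus), read by reporter gene assay, with a stated time of 24 h; on this read-out lower numbers stand for an effect already at smaller amounts and higher numbers for an effect only at larger amounts of compound
compound 2 `COc1ccc2nc(NC(=O)CNC(=O)c3nn(-c4ccccc4)c(=O)c4ccccc34)sc2c1`: 210 nM in this assay

Compound 2 holds the higher of the two numbers in this assay, the gap being a 6.0-fold higher number from compound 1 to compound 2 (0.78 log units; beyond the scatter). Compound 3 `O=C(CNC(=O)c1nn(-c2ccccc2)c(=O)c2ccccc12)Nc1nc2ccc(C(F)(F)F)cc2s1` differs from compound 2 by trifluoromethyl in place of methoxy on an aromatic carbon. Within the data shown here, no measured step exchanges a methoxy for a trifluoromethyl; the single known step, a 6.0-fold higher number from compound 1 to compound 2 (0.78 log units; beyond the scatter), only shows that a change at this aromatic carbon can move the number beyond the scatter. For compound 3 a modest move toward lower numbers is therefore expected, as a 2.1-fold lower number from compound 2 to compound 3 (0.32 log units; beyond the scatter). Compound 3 is estimated at 100 nM in this assay, between 25 nM and 400 nM.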

Compound 3, half-maximal effective concentration: 110 nM
For compound 3 the middle estimate is 1.1-fold (0.04 log units) below the measured one, within the range that was stated.
By their numbers in this assay, from the lowest: compound 1; then compounds 3 and 2 (each within the scatter of the next).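

In this assay the exchange of methoxy for trifluoromethyl at this aromatic carbon gives a 1.9-fold lower number from compound 2 to compound 3 (0.28 log units; within the scatter), so the two groups cannot be told apart here. The exchange of methyl for trifluoromethyl gives a 3.1-fold higher number from compound 1 to compound 3 (0.50 log units; beyond the scatter), so among the three groups methyl alone stands apart from both others. No measurement on hand offers an explanation for this. The compounds shown leave open where a chlorine atom, an amine or a longer alkyl chain at this carbon would fall relative to methyl and the other two groups.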